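This account rests on a few compounds, and the source may have more. Where it says the series, first, only, none or still open, it means among the compounds named here.

In a functional assay on A549 cells (Homo sapiens) for cytotoxicity, read by MTT assay, with a stated time of 72 h (a lower number here means a stronger inhibitor, a higher number a weaker inhibitor), compound 1 (`COc1ccc(/C=N/NC(=O)Nc2cc3c(Nc4ccc(F)c(Cl)c4)ncnc3cc2O[C@H]2CCOC2)cc1`) gives 33100 nM and compound 2 (`COc1ccc(/C=N/NC(=O)Nc2cc3c(Nc4ccc(F)c(Cl)c4)ncnc3cc2OC)cc1`) gives 28100 nM in the same test. Within the data shown here, compound 2 therefore stands level with compound 1, the only other compound measured, since the single measured step, a 1.2-fold lower number from compound 1 to compound 2 (0.07 log units; within the scatter), does not separate them. Compound 3 (`COc1cc2ncnc(Nc3ccc(F)c(Cl)c3)c2cc1NC(=O)N/N=C/c1ccc(O)cc1`) changes the 4-methoxyphenyl of compound 2 to 4-hydroxyphenyl (hydrogen in place of methyl on an oxygen on an aromatic ring) , which places hydrogen in place of methyl on an oxygen on an aromatic ring. The measured step concerns a different oxygen, so no measurement speaks directly to this change, and its small size offers only weak guidance. No shift beyond the scatter is therefore expected, and the estimated change is a 1.3-fold lower number from compound 2 to compound 3 (0.11 log units; within the scatter) in this assay with wide uncertainty. For compound 3 the estimate is 22000 nM with an expected range from 9000 nM to 50000 nM in this test.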

Compound 3, half-maximal inhibitory concentration: 7610 nM
For compound 3 the middle estimate is 2.9-fold (0.46 log units) above the measured one; measured number outside the range, below it.
By their numbers in this assay, from the lowest: compound 3; then compounds 2 and 1 (each within the scatter of the next).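

Among the compounds shown, the methyl on the oxygen of the 4-methoxyphenyl is the first place where a single change separates two compounds in this assay. Going from methoxy to hydroxy gives a 3.7-fold lower number from compound 2 to compound 3 (0.57 log units; beyond the scatter), a modest step, whereas the exchange on the other oxygen, the one on the core, gives a 1.2-fold lower number from compound 1 to compound 2 (0.07 log units; within the scatter) and does not separate its pair. Nothing available explains why the hydrogen in place of methyl matters here.

From the compounds shown here alone, whether an amine or a carboxylic acid in place of the hydroxy on this phenyl would give a number like that of compound 3 remains open. Going by these compounds, it is also open whether the same change from methoxy to hydroxy would shift the number to a similar extent with the oxolan-3-yl group of compound 1 on the core.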